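Swapping the aminopyrazole for a dimethyloxazole on the core

The source may report more compounds than this note shows. Statements on the series, on what has been measured and on what is new or still open speak of the compounds shown alone.

Values measured so far in a functional assay on HCT-116 cells (Homo sapiens) for antiproliferative activity, read by MTT assay, with a stated time of 72 h (on this read-out lower numbers stand for stronger inhibition and higher numbers for weaker inhibition), are these:

Compound 1 `Cc1noc(C)c1-c1nn(Cc2ccc(C(=O)NC3CC(C)(C)N([O])C(C)(C)C3)cc2)c(=O)c2ccccc12` gives 36800 nM in inhibition
Compound 2 `Cc1noc(C)c1-c1nn(Cc2ccc(C(=O)NC3CCN(C)CC3)cc2)c(=O)c2ccccc12` gives 84900 nM in inhibition
Compound 3 `Cn1cc(Nc2nn(Cc3ccc(C(=O)NC4CCCCC4)cc3)c(=O)c3ccccc23)cn1` gives 5400 nM in inhibition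

Compound 3 has the lowest of the three numbers, and both other values lie beyond the scatter from it. Compound 4 `Cc1noc(C)c1-c1nn(Cc2ccc(C(=O)NC3CCCCC3)cc2)c(=O)c2ccccc12` keeps the amide side of compound 3 and changes one group on the shared core: 3,5-dimethyl-1,2-oxazol-4-yl in place of (1-methyl-1H-pyrazol-4-yl)amino on an aromatic carbon is the whole difference.

Among the compounds with values here, no measured step covers this exchange directly. Within the data shown here, the only step between measured compounds, a 2.3-fold higher number from compound 1 to compound 2 (0.36 log units; beyond the scatter), is modest and lies on the amide nitrogen, so it shows only how far the number moved with a change on that side. The nearest evidence is indirect: compound 1 at 36800 nM and compound 2 at 84900 nM both carry the entering 3,5-dimethyl-1,2-oxazol-4-yl group. Compound 3 gives 5400 nM, and the numbers of the other two both stand above that one, even though their amide groups differ from its own.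

A step toward weaker inhibition in this assay is therefore expected, estimated as a 4.6-fold higher number from compound 3 to compound 4 (0.67 log units; beyond the scatter) and beyond the scatter. The estimate for compound 4 is 25000 nM, with an expected range from 8000 nM to 70000 nM.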

Compound 4, half-maximal inhibitory concentration: > 100000 nM
Compound 4: a limit, no number (the forecaster's own chance of this, stated with the estimate: 10%); middle value at least 4.0-fold (0.60 log units) away from the limit.
By their numbers in this assay, from the lowest: compound 3; then compound 1; then compound 2. At a limit, above all of these: compound 4.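

In this assay, with the cyclohexyl amide held fixed, the exchange on the aromatic carbon next to the ring nitrogen can now be read directly: an at least 18-fold higher number from compound 3 to compound 4 (1.26 log units; beyond the scatter), a large step toward weaker inhibition and the only reading of this exchange among the compounds shown. Compound 4 stands at a limit of the assay, not at a number, so this step gives only a floor on the change: the limit of > 100000 nM in this assay, at which 1 of the 4 values shown sits. With the 3,5-dimethyl-1,2-oxazol-4-yl group kept on the core, the amide side can also be compared: the change is an at least 2.7-fold higher number from compound 1 to compound 4 (0.43 log units; beyond the scatter), whereas the other comparison, an at least 1.1-fold higher number from compound 2 to compound 4 (0.07 log units; that floor lies within the scatter), gives no order, so cyclohexyl brings no recovery of inhibition with this group in place.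

The true size of the step on the core remains unknown, and the compounds shown cannot separate the loss of the amino link from the change of ring. A 1-methyl-1H-pyrazol-4-yl group set directly on the aromatic carbon, or a 3,5-dimethyl-1,2-oxazol-4-yl group attached through an amino link, would tell these two parts apart.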